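Fluoro in Place of Amino: What to Expect

This account rests on a few compounds, and the source may have more. Where it says the series, first, only, none or still open, it means among the compounds named here.

Measured in a functional assay on A549 cells (Homo sapiens) for cytotoxicity, read by MTT assay, with a stated time of 72 h; on this read-out higher numbers stand for weaker inhibition and lower numbers for stronger inhibition:
Compound 1 `O=S(=O)(c1ccccc1)c1nc2ccccc2nc1Nc1ccc(F)cc1` gives > 50000 nM, a limit of the assay rather than a number.
Compound 2 `COc1ccc(Nc2nc3ccccc3nc2S(=O)(=O)c2ccc(Br)cc2)cc1` gives 3340 nM.
Compound 3 `Nc1ccc(Nc2nc3ccccc3nc2S(=O)(=O)c2ccc(Br)cc2)cc1` gives 1020 nM.

Compound 3 has the lowest of the two numbers measured in this assay; the nearest is compound 2, and the step of a 3.3-fold lower number from compound 2 to compound 3 (0.52 log units; beyond the scatter) lies beyond the scatter. Compound 1 reaches only the assay's limit (the limit of > 50000 nM in this assay, at which 1 of the 3 values shown sits), so no number stands for it.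

Compound 4 `O=S(=O)(c1ccc(Br)cc1)c1nc2ccccc2nc1Nc1ccc(F)cc1` has not yet been measured. It differs from compound 3 in one place: fluoro in place of amino on an aromatic carbon. Among the measured compounds shown here, only one measured step bears on this change, a 3.3-fold lower number from compound 2 to compound 3 (0.52 log units; beyond the scatter), in which amino arrived and the number fell. Here amino leaves again, so the number would be expected to rise. Compound 1, which carries the same (4-fluorophenyl)amino group as compound 4 but differs elsewhere in the structure, sits at the limit. Taken together these point to a markedly higher number for compound 4, expected as a 12-fold higher number from compound 3 to compound 4 (1.07 log units; beyond the scatter). Compound 4 is therefore estimated at 12000 nM, with a likely range from 3000 nM to 50000 nM, and with a real chance that only a limit is reported.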

Compound 4, half-maximal inhibitory concentration: 4360 nM
Compound 4: the middle estimate sits 2.8-fold (0.44 log units) above what was measured, within the range that was stated.
By their numbers in this assay, from the lowest: compound 3; then compounds 2 and 4 (each within the scatter of the next). At a limit, above all of these: compound 1.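

In this assay, amino now stands apart from two other groups at this place, para to a large group: fluoro in its stead gives a 4.3-fold higher number from compound 3 to compound 4 (0.63 log units; beyond the scatter), while fluoro and methoxy cannot be told apart, with a 1.3-fold higher number from compound 2 to compound 4 (0.12 log units; within the scatter). Among the three compounds that carry bromo, then, only compound 3, with its amino group, stands out with a lower number. With fluoro held in place, a change elsewhere, bromo in place of hydrogen, gives an at least 11-fold lower number from compound 1 to compound 4 (1.05 log units; beyond the scatter), so the fluoro group does not by itself bring the result of compound 1, and the value for compound 1 is a limit, which leaves the true size of this step unknown: the limit of > 50000 nM in this assay, at which 1 of the 4 values shown sits.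

Among the compounds shown here, only three groups at this place can be compared, so it remains open whether a hydroxyl group or a dimethylamino group would side with amino or with fluoro and methoxy. The compounds shown also cannot tell whether bromo in place of hydrogen would give a step of similar size with amino at this place.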